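A few compounds are considered here, and "the series" means these few. Any claim that something is new, unique, unknown or untested is made for them only; others in the source may bear on it.

Measured in a functional assay on HepG2 cells (Homo sapiens) for antiproliferative activity, read by MTT assay, with a stated time of 48 h; on this read-out lower numbers stand for stronger inhibition and higher numbers for weaker inhibition:
- compound 1 `COc1ccc(CN2C(=O)C(=O)c3cc(-c4cccc(OC)c4)ccc32)cc1`: 1890 nM
- compound 2 `COc1ccc(CN2C(=O)C(=O)c3cc(-c4ccc(F)cc4)ccc32)cc1`: 3150 nM
- compound 3 `COc1ccc(CN2C(=O)C(=O)c3cc(-c4ccc(C#N)cc4)ccc32)cc1`: 890 nM

Compound 3 has the lowest of the three numbers, with compound 1 nearest and compound 2 furthest. The next analogue is compound 4 `COc1ccc(CN2C(=O)C(=O)c3cc(-c4ccc(O)cc4)ccc32)cc1`, which differs from compound 3 in one group: hydroxy in place of cyano on an aromatic carbon. This places hydroxy in place of cyano on an aromatic carbon, para to a large group.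

For the measured compounds named here, three measured steps bear on this change. The closest is a 3.5-fold lower number from compound 2 to compound 3 (0.55 log units; beyond the scatter), where cyano replaces fluoro at the same place. The step of a 2.1-fold lower number from compound 1 to compound 3 (0.33 log units; beyond the scatter) points the same way. The remaining step, a 1.7-fold higher number from compound 1 to compound 2 (0.22 log units; within the scatter), does not separate the two compounds without cyano. Going by the values given here, both comparisons involving compound 3 therefore favour the cyano group, but only modestly, and no hydroxy analogue has yet been measured. Moving away from cyano is thus expected to raise the number in this assay, by a modest step of similar size, with a wide margin. The expected change is a 2.2-fold higher number from compound 3 to compound 4 (0.35 log units; beyond the scatter). For compound 4 the estimated value is 2000 nM, with an expected range of 800 nM to 5000 nM.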

Compound 4, half-maximal inhibitory concentration: > 10000 nM
Compound 4: no number, only a limit; the forecaster's own chance of this, stated with the estimate: 3%; middle value at least 5.0-fold (0.69 log units) away from the limit.
By their numbers in this assay, from the lowest: compound 3; then compounds 1 and 2 (each within the scatter of the next). At a limit, above all of these: compound 4.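

In this assay compound 4 gives > 10000 nM, a limit of the assay and not a number, and the series reaches that limit only here: the limit of > 10000 nM in this assay, at which 1 of the 4 values shown sits.
At this aromatic carbon, para to a large group, hydroxy in place of cyano gives an at least 11-fold higher number from compound 3 to compound 4 (1.05 log units; beyond the scatter), a large step, so the group held here can shift the read-out much further than compounds 1, 2 and 3 alone suggested.
The loss is not measured against cyano alone, since the other two comparisons also run the same way, with an at least 3.1-fold higher number from compound 2 to compound 4 (0.50 log units; beyond the scatter) and an at least 5.2-fold higher number from compound 1 to compound 4 (0.72 log units; beyond the scatter), and hydroxy therefore sits behind all three groups shown on this aryl ring.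

As far as these compounds go, with only a limit for compound 4, the full size of these steps stays unknown, and each one gives only a lower bound.
From the compounds shown here alone, whether an amine, a carboxylic acid or a 4-methoxyphenyl group at this place would stay near compound 3 or fall toward compound 4 remains open, as does the question of whether the hydroxy penalty would hold with a different group on the nitrogen of the shared core.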